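Series notes: aryl substituents on the shared core, paw edema

A few compounds are considered here, and "the series" means these few. Any claim that something is new, unique, unknown or untested is made for them only; others in the source may bear on it.

Measured compounds:
compound 1 `CCc1nn2c(C(C)c3ccc(CC(C)C)cc3)nnc2s1` — 49%
compound 2 `CC(C)Cc1ccc(C(C)c2nnc3sc(-c4ccc(Br)cc4)nn23)cc1` — 69%
compound 3 `CC(C)Cc1ccc(C(C)c2nnc3sc(-c4ccccc4Cl)nn23)cc1` — 57%

In a functional assay on the whole organism (strain Wistar albino) for inhibition, with Rattus norvegicus as the target, read by paw edema, with stated times of 30 min and 1.5 h, at a dose of 20 mg/kg by the oral route (on this read-out lower numbers stand for less inhibition and higher numbers for more inhibition at the one dose given (going by the name of the read-out)), compound 3 stands second of the three numbers. Its nearest neighbour is compound 1, which in this assay gives 49%, a gap within the scatter; the furthest is compound 2, which gives 69%, and the step of a number 12 percentage points lower from compound 2 to compound 3 (beyond the scatter) is beyond the scatter. The other step, a number 20 percentage points higher from compound 1 to compound 2 (beyond the scatter), is likewise beyond the scatter, while a number 8 percentage points higher from compound 1 to compound 3 (within the scatter) stays within it.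

Compound 4 `CC(C)Cc1ccc(C(C)c2nnc3sc(-c4ccc([N+](=O)[O-])cc4Cl)nn23)cc1` has not been measured. It differs from compound 3 by nitro in place of hydrogen on an aromatic carbon. Among the measured compounds shown here, no measured step exchanges hydrogen for nitro, so the expectation rests on the steps among the aryl groups: the 4-bromophenyl of compound 2, carrying a group para to the large group, gives the highest number, and the step from it to the 2-chlorophenyl of compound 3 was a modest fall. Adding a nitro at the corresponding place on the ring of compound 3 is therefore expected to give a modest rise, a number 7 percentage points higher from compound 3 to compound 4 (within the scatter), though a result within the scatter of compound 3 would not surprise. Compound 4 is estimated at 64%, with a range of 50% to 78%.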

Compound 4, a percentage reported as inhibition, in the whole organism at one dose (the size of the read-out at that dose, not a potency): 59%
Beside the measured number, compound 4's estimate is 5 percentage points above it; the range from low to high includes it.
By their numbers in this assay, from the lowest: compounds 1, 3, 4 and 2 (each within the scatter of the next, the first and the last beyond it).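

In this assay, nitro in place of hydrogen on the aromatic carbon para to a large group and meta to a chloro group gives a number 2 percentage points higher from compound 3 to compound 4 (within the scatter), so this place on the 2-chlorophenyl ring accepts nitro with no change beyond the scatter. The new group also blurs the separation among the substituents on the shared core: a number 10 percentage points lower from compound 2 to compound 4 (within the scatter) and a number 10 percentage points higher from compound 1 to compound 4 (within the scatter) both stay within the scatter, whereas a number 12 percentage points lower from compound 2 to compound 3 (beyond the scatter) lay beyond it, which leaves compound 4 distinct from neither end of the series. No available data on the compounds bear on what lies behind this flat result.

Still open, on these data alone, is how a 4-nitrophenyl group without the chloro group would read against the 4-bromophenyl group of compound 2, which would show whether the chloro group or the group para to the large group governs the number. Also open, as far as these compounds go, is whether an amine or a carboxylic acid at this same place on the 2-chlorophenyl ring would stay as close to compound 3 as nitro does.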